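The source may report more compounds than this note shows. Statements on the series, on what has been measured and on what is new or still open speak of the compounds shown alone.

Compounds measured so far:
compound 1 `CC(Sc1nc2c(cnn2C)c(=O)n1-c1ccccc1)c1cccc(F)c1` — 151 nM in an assay on isolated protein for inhibition of aldehyde dehydrogenase 1A1 (Homo sapiens); on this read-out lower numbers stand for stronger inhibition and higher numbers for weaker inhibition
compound 2 `CC(Sc1nc2c(cnn2C)c(=O)n1-c1ccccc1)c1cccnc1` — 139 nM in this assay

Within the data shown here, compound 2 gives the lowest of the two numbers in this assay, but its only neighbour is compound 1 and the step of a 1.1-fold lower number from compound 1 to compound 2 (0.04 log units; within the scatter) lies within the scatter, so the two are not separated. Compound 3 `CC(Sc1nc2c(cnn2C)c(=O)n1-c1ccccc1)c1cncnc1` is not yet measured. It differs from compound 2 in one place: pyrimidin-5-yl in place of pyridin-3-yl on a saturated chain carbon bound to a saturated chain carbon and a sulfur. Among the measured compounds shown here, the only measured step that bears on this change is a 1.1-fold lower number from compound 1 to compound 2 (0.04 log units; within the scatter), where one six-membered ring with a single ring nitrogen replaced a fluorine-bearing ring without moving the number beyond the scatter. For the measured compounds named here, no step with a second ring nitrogen exists, so nothing more can be inferred. On that basis compound 3 is expected to sit close to compound 2 in this assay, with a step of a 1.2-fold higher number from compound 2 to compound 3 (0.09 log units; within the scatter) that is not expected to go beyond the scatter. The estimate for compound 3 in this assay is 170 nM, with a range from 70 nM to 420 nM.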

Compound 3, half-maximal inhibitory concentration: 94 nM
For compound 3 the middle estimate is 1.8-fold (0.26 log units) above the measured one, and the stated range covers the measured number.
By their numbers in this assay, from the lowest: compounds 3, 2 and 1 (each within the scatter of the next).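

In this assay, pyrimidin-5-yl at this position, on a saturated chain carbon bound to a saturated chain carbon and a sulfur, gives a 1.5-fold lower number from compound 2 to compound 3 (0.17 log units; within the scatter), so this change from pyridin-3-yl does not separate the two compounds. The comparison with the 3-fluorophenyl group reads the same, with a 1.6-fold lower number from compound 1 to compound 3 (0.21 log units; within the scatter), and all three six-membered aromatic rings therefore remain unresolved at this position, whether they carry no ring nitrogen, as in compound 1, or the hetero atoms of compound 2 or compound 3. No supporting data bear on this result.

As far as these compounds go, it remains open whether a non-aromatic group at this position, such as a morpholine or a piperidine, would give a step beyond the scatter. A carboxylic acid or an amine on this ring, or an ethyl group in place of the chain methyl, is equally untested in the compounds shown.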